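The compounds below may be only part of what the source reports. "The series", "measured", "known", "first", "only" and "open" are said of these compounds alone.

- Compound 1 `CC1CCN(Cc2ccc3nc(NC(=O)N/N=C/c4c[nH]c5ccccc45)sc3c2)CC1`: 2460 nM
- Compound 2 `CCN(CC)Cc1ccc2nc(NC(=O)N/N=C/c3cn(Cc4ccc(C)cc4)c4ccccc34)sc2c1`: 2010 nM

In a functional assay on MDA-MB-231 cells (Homo sapiens) for cytotoxicity, read by MTT assay, with a stated time of 72 h (on this read-out higher numbers stand for weaker inhibition and lower numbers for stronger inhibition), compound 2 gives 2010 nM and compound 1 gives 2460 nM, which lie within the usual scatter of each other, so the two numbers cannot be told apart. Compound 3 `Cc1ccc(Cn2cc(/C=N/NC(=O)Nc3nc4ccc(CN5CCC(C)CC5)cc4s3)c3ccccc32)cc1` differs from compound 2 by one change: 4-methylpiperidin-1-yl in place of diethylamino on a saturated chain carbon bound to an aromatic carbon, with 4-methylpiperidin-1-yl in place of diethylamino on a saturated chain carbon bound to an aromatic carbon. Among the measured compounds shown here, no measured pair shows this change alone, so no step beyond the scatter is expected in this assay. The expected change is a 1.1-fold lower number from compound 2 to compound 3 (0.05 log units; within the scatter). Compound 3 is estimated at 1800 nM, with an expected range of 700 nM to 4500 nM.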

Compound 3, half-maximal inhibitory concentration: 1140 nM
Estimate against measurement, compound 3: 1.6-fold (0.20 log units) above, and the stated range covers the measured number.
By their numbers in this assay, from the lowest: compounds 3, 2 and 1 (each within the scatter of the next, the first and the last beyond it).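

In this assay, 4-methylpiperidin-1-yl in place of diethylamino on a saturated chain carbon bound to an aromatic carbon gives a 1.8-fold lower number from compound 2 to compound 3 (0.25 log units; within the scatter), so these two amines cannot be told apart here. Among the compounds shown here, by contrast, 4-methylbenzyl in place of hydrogen on an aromatic nitrogen gives a 2.2-fold lower number from compound 1 to compound 3 (0.33 log units; beyond the scatter), the first single change here to clear the usual scatter, though only modestly. Nothing available explains either result. Still open, going by these compounds, is how a plain methyl or an unsubstituted benzyl on that nitrogen would compare, and how a morpholin-4-yl group would fare on the chain carbon.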